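This account rests on a few compounds, and the source may have more. Where it says the series, first, only, none or still open, it means among the compounds named here.

Of the compounds shown here, three built on one shared core have so far been tested in a functional assay, with a stated time of 150 min; a higher number here means a weaker inhibitor, a lower number a stronger inhibitor. Compound 1 `COc1ccc(-c2nc(NN)n(C)c(=O)c2C#N)cc1` gives 56 ug/mL in this assay. Compound 3 `COc1cccc(-c2nc(NN)n(C)c(=O)c2C#N)c1OC` carries a 2,3-dimethoxyphenyl group where compound 1 has a methoxyphenyl group; in this assay compound 3 gives 54 ug/mL. Compound 2 `CCOC(=O)c1cnn(-c2nc(-c3cccc(OC)c3OC)c(C#N)c(=O)n2C)c1N` keeps the 2,3-dimethoxyphenyl group of compound 3 but differs from it elsewhere on the core; in this assay compound 2 gives 69 ug/mL. Among the three numbers, compound 2 has the highest, yet it lies within the usual scatter of both compound 1 and compound 3, so the three values cannot be told apart.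

Compound 4 `CCOC(=O)c1cnn(-c2nc(-c3ccccc3Cl)c(C#N)c(=O)n2C)c1N` has not been measured. It differs from compound 2 in one place: 2-chlorophenyl in place of 2,3-dimethoxyphenyl on an aromatic carbon. Among the compounds with values here, no measured pair shows this particular swap, so no direct step is available. The only related hint comes from compound 1 and compound 3, whose aryl groups differ while their values sit within the scatter of each other. On that basis the step from compound 2 to compound 4 is expected to be none beyond the scatter, as a 1.1-fold lower number from compound 2 to compound 4 (0.03 log units; within the scatter) expresses. Compound 4 is therefore estimated at 65 ug/mL, with a range from 30 ug/mL to 140 ug/mL.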

Compound 4, half-maximal inhibitory concentration: 93 ug/mL
Beside the measured number, compound 4's estimate is 1.4-fold (0.16 log units) below it; measured number inside the range.
By their numbers in this assay, from the lowest: compounds 3, 1, 2 and 4 (each within the scatter of the next).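

Placing 2-chlorophenyl where 2,3-dimethoxyphenyl stood, on the aromatic carbon ortho to a cyano group, gives the first direct reading of a change at this position with the rest of the molecule held fixed: in this assay, the swap is a 1.3-fold higher number from compound 2 to compound 4 (0.13 log units; within the scatter). Even though the oxygen atoms and hydrogen-bond acceptors of 2,3-dimethoxyphenyl give way to a chlorine, this step cannot be told apart from repeat-measurement noise, so this assay shows no real difference between these two aryl groups at this position on the core of compound 2. No other measurement bears on this result, so it offers no explanation for how the two groups compare.

On these data alone, both groups compared here are six-membered aromatic rings of carbon only, so it remains open how a pyridine ring, a morpholine ring or a simple propyl chain would read at this position. As far as these compounds go, it also remains open whether an aryl group carrying an amine or a carboxylic acid would produce a step beyond the scatter.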